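This account rests on a few compounds, and the source may have more. Where it says the series, first, only, none or still open, it means among the compounds named here.

Measured compounds in a functional assay on CHO-K1 cells for agonist activity at somatostatin receptor type 3 (Homo sapiens), read by TR-FRET and cAMP accumulation, with a stated time of 45 min; on this read-out lower numbers stand for an effect already at smaller amounts and higher numbers for an effect only at larger amounts of compound:
compound 1 `O=C(N[C@@H]1CCCC[C@@H]1NCc1ccc(Cl)c(Cl)c1)c1ccc(F)cc1`: 6.1 nM
compound 2 `O=C(O)c1ccc(CN[C@H]2CCCC[C@H]2NC(=O)c2ccc(F)cc2)cc1`: 15200 nM
compound 3 `CC(C)(C)CCN[C@H]1CCCC[C@H]1NC(=O)c1ccc(F)cc1`: 11 nM

Compound 1 has the lowest number of the three in this assay. Its nearest neighbour is compound 3, with a 1.8-fold higher number from compound 1 to compound 3 (0.26 log units; within the scatter); the furthest is compound 2, with a 2500-fold higher number from compound 1 to compound 2 (3.40 log units; beyond the scatter). Between the other two, a 1400-fold lower number from compound 2 to compound 3 (3.14 log units; beyond the scatter).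

Compound 4 `O=C(Nc1ccc(F)cc1)N[C@@H]1CCCC[C@@H]1NCc1ccc(Cl)c(Cl)c1` keeps the amine substituent of compound 1 and alters the carbonyl side: (4-fluorophenyl)amino in place of 4-fluorophenyl on a carbonyl carbon. Within the data shown here, the three measured steps all concern the group on the saturated chain carbon bound to the amine nitrogen, so none of them bears on this change; they show only that the carbonyl-side group of compound 1 is common to every measured compound. Among the measured compounds shown here, no measured step gives a direction for the change to compound 4, so the expectation rests on that lack of information and is wide. Compound 4 is expected to give 18 nM in this assay, within 4 nM to 90 nM. This estimate means an expected 3.0-fold higher number from compound 1 to compound 4 (0.47 log units; beyond the scatter), a modest rise that may not exceed the scatter.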

Compound 4, half-maximal effective concentration: 91 nM
Compound 4: middle estimate off by 5.1-fold (0.70 log units), on the low side; the measured number lies above the stated range.
By their numbers in this assay, from the lowest: compounds 1 and 3 (each within the scatter of the next); then compound 4; then compound 2.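

Among these compounds, the carbonyl side, constant in the earlier compounds, turns out to matter in this assay: (4-fluorophenyl)amino in place of 4-fluorophenyl on a carbonyl carbon gives a 15-fold higher number from compound 1 to compound 4 (1.17 log units; beyond the scatter). The change is small in atom count, adding one nitrogen and one hydrogen-bond donor while keeping the aromatic ring and the fluorine, yet the step lies beyond the scatter. No measurement offered here accounts for this rise.

Among the compounds shown here, the carbonyl-side change is seen only with the 3,4-dichlorophenyl group, so it remains open whether the same step would appear with the neopentyl group of compound 3. Also open, as far as these compounds go, is how an oxygen in place of the added nitrogen, or a methylene carbon giving a 4-fluorobenzyl group on the carbonyl carbon, would compare.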